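Little Movement Expected from Chloro to Methyl

This account rests on a few compounds, and the source may have more. Where it says the series, first, only, none or still open, it means among the compounds named here.

Values in a functional assay; on this read-out lower numbers stand for stronger inhibition and higher numbers for weaker inhibition
- Compound 1 `CC(C)=CCOc1ccc2c(c1)OC(c1ccccc1)CC2=O` gives 6070 nM
- Compound 2 `CC(C)=CCOc1ccc2c(c1)OC(c1ccc(Cl)cc1)CC2=O` gives 6970 nM
- Compound 3 `CC(C)=CCOc1cc(O)c2c(c1)OC(c1ccc(Cl)cc1)CC2=O` gives 7020 nM

Compound 3, at 7020 nM, lies within the scatter of compound 1 and compound 2. Compound 4 `CC(C)=CCOc1cc(O)c2c(c1)OC(c1ccc(C)cc1)CC2=O` differs from it by methyl in place of chloro on an aromatic carbon, the change from 4-chlorophenyl to 4-methylphenyl (methyl in place of chloro on an aromatic carbon). Among the compounds with values here, no measured compound carries this methyl. The nearest evidence is the arrival of chloro in place of hydrogen, a 1.1-fold higher number from compound 1 to compound 2 (0.06 log units; within the scatter). The hydroxy step, a 1.0-fold higher number from compound 2 to compound 3 (0.00 log units; within the scatter), was equally small. Neither step exceeds the scatter, so no step beyond it is expected in this assay. The expected change is a 1.1-fold lower number from compound 3 to compound 4 (0.03 log units; within the scatter). Compound 4 is estimated at 6500 nM, with an expected range from 3000 nM to 14000 nM.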

Compound 4, half-maximal inhibitory concentration: 4360 nM
Beside the measured number, compound 4's estimate is 1.5-fold (0.17 log units) above it; low and high end bracket the measured number.
By their numbers in this assay, from the lowest: compounds 4, 1, 2 and 3 (each within the scatter of the next).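

In this assay the exchange of chloro for methyl gives a 1.6-fold lower number from compound 3 to compound 4 (0.21 log units; within the scatter). This position on the aromatic ring, which took chloro in place of hydrogen without a step beyond the scatter, therefore also takes methyl in place of chloro without one, so neither group is set apart from hydrogen or from the other here. No measurement at hand explains this result. The compounds shown leave open whether an amine, a carboxylic acid or a longer chain at this position would give a step beyond the scatter.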